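The source may hold more compounds than are shown below. What is called first, only, known or untested is meant among the compounds shown, and "the series" means these compounds.

Measured so far:
- compound 1, `CC(C)C(=O)OCOC(=O)C1=C(S[C@@H]2CN[C@H](C(=O)Nc3cccc(C(=O)O)c3)C2)[C@H](C)[C@@H]2[C@@H]([C@@H](C)O)C(=O)N12`, gives 0% in an ADME assay on a cell-free system (plasma, Rattus norvegicus) for metabolic stability, read by LC-MS, with a stated time of 60 min, at 37 degrees C, tested at 50 uM; a lower number here means that less of the compound is left, a higher number that more of the compound is left
- compound 2, `CCC(CC)C(=O)OCOC(=O)C1=C(S[C@@H]2CN[C@H](C(=O)Nc3cccc(C(=O)O)c3)C2)[C@H](C)[C@@H]2[C@@H]([C@@H](C)O)C(=O)N12`, gives 0%
- compound 3, `C[C@@H](O)[C@H]1C(=O)N2C(C(=O)OCOC(=O)C3CCCCC3)=C(S[C@@H]3CN[C@H](C(=O)Nc4cccc(C(=O)O)c4)C3)[C@H](C)[C@H]12`, gives 0%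

All three compounds share one core and differ only in the group attached to a carbonyl carbon at the outer end of the molecule. Compound 3 stands level with the other two: no change at the digits printed from compound 1 to compound 3 (within the scatter), no change at the digits printed from compound 2 to compound 3 (within the scatter), and no change at the digits printed from compound 1 to compound 2 (within the scatter). Within the scatter of this kind of measurement, nothing of these compounds is left after the stated time.

Compound 4, `CCOC(=O)OCOC(=O)C1=C(S[C@@H]2CN[C@H](C(=O)Nc3cccc(C(=O)O)c3)C2)[C@H](C)[C@@H]2[C@@H]([C@@H](C)O)C(=O)N12`, is the next step from compound 3, and it changes that same carbonyl carbon once more: ethoxy in place of cyclohexyl on a carbonyl carbon. Cut one bond further out, the change reads cyclohexylcarbonyl to ethoxycarbonyl.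

The three measured steps bear directly on this one, as each of them also swapped the group on that carbonyl carbon, and none of them produced a change beyond the scatter. An ethoxy group has not been tried in this series, so the new step is not an exact repeat of any measured one. Still, on the numbers shown, the expected step is a number 2 percentage points higher from compound 3 to compound 4 (within the scatter), that is, no change beyond the scatter. Compound 4 is therefore estimated at 2%, with a range from 0% to 20%.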

Compound 4, percent of the compound remaining: 0%
Compound 4: the middle estimate sits 2 percentage points above what was measured; the measured number falls inside the stated range.
By their numbers in this assay, from the lowest: compounds 1, 2, 3 and 4 (each within the scatter of the next).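

In this assay the ethoxy group behaves like every group before it on this carbonyl carbon: there is no change at the digits printed from compound 3 to compound 4 (within the scatter), no change at the digits printed from compound 2 to compound 4 (within the scatter) and no change at the digits printed from compound 1 to compound 4 (within the scatter). Ethoxy is the only group of the four that joins this carbonyl carbon through an oxygen rather than a carbon, so the result extends the flat picture from branched and ring-bearing carbon groups to a group of a different kind, one that has no ring and counts one hydrogen-bond acceptor where cyclohexyl counts none. No measurement shown here gives any reason why all four compounds read alike.

All four readings sit at the very bottom of the scale, so this single end-point reading cannot tell whether the compounds disappear at similar speeds or whether some disappear much sooner than others within the stated time. From the compounds shown here alone, it also remains open whether an amine on this carbonyl carbon, or a longer chain in place of the ethyl part of ethoxy, would leave any compound present at the end of this assay.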